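The source may hold more compounds than are shown below. What is called first, only, known or untested is meant among the compounds shown, and "the series" means these compounds.

The measured compounds:
compound 1, `CN(C)CCNC(=O)c1c(O)c2cccnc2n(-c2ccccc2)c1=O`, inhibition 22.6%
compound 2, `Cc1ccc(NC(=O)c2c(O)c3cccnc3n(-c3ccccc3)c2=O)cc1`, inhibition -3.5%

In a functional assay on the whole organism for inhibition, with Rattus norvegicus as the target, read by paw edema, at a dose of 100 mg/kg by the oral route (on this read-out higher numbers stand for more inhibition at the one dose given (going by the name of the read-out) and lower numbers for less inhibition), compound 1 gives 22.6%, and compound 2 gives -3.5%. Within the data shown here, compound 2 thus stands lowest of the two numbers; its nearest neighbour is compound 1, and the only measured step between them is a number 26.1 percentage points lower from compound 1 to compound 2 (beyond the scatter), a change of the whole group on the amide-type nitrogen.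

Compound 3, `O=C(Nc1ccc(Cl)cc1)c1c(O)c2cccnc2n(-c2ccccc2)c1=O`, has not yet been measured in this assay. It differs from compound 2 by chloro in place of methyl on an aromatic carbon, so that 4-methylphenyl becomes 4-chlorophenyl. Among the measured compounds shown here, no measured step bears on a change of this kind: the one step known, a number 26.1 percentage points lower from compound 1 to compound 2 (beyond the scatter), exchanges the entire substituent on the amide-type nitrogen and says nothing about swapping one atom on the ring of 4-methylphenyl. With no guide to a direction, the step from compound 2 to compound 3 is expected to be a number 3.5 percentage points higher from compound 2 to compound 3 (within the scatter), not beyond the scatter. Compound 3 is therefore estimated at 0%, with a range from -15% to 15%.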

Compound 3, a percentage reported as inhibition, in the whole organism at one dose (the size of the read-out at that dose, not a potency): 11.6%
Estimate against measurement, compound 3: 11.6 percentage points below; the measured number falls inside the stated range.
By their numbers in this assay, from the lowest: compound 2; then compound 3; then compound 1.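

Swapping a single atom on the ring of 4-methylphenyl is enough to move the read-out: on an aromatic carbon, para to a large group, chloro in place of methyl gives in this assay a number 15.1 percentage points higher from compound 2 to compound 3 (beyond the scatter), something the earlier comparison could not show, since it exchanged the whole substituent on the amide-type nitrogen. The ring substituent therefore matters, but it does not recover the level seen with the basic-free comparison aside: putting 4-chlorophenyl in place of 2-(dimethylamino)ethyl on the amide-type nitrogen still gives a number 11 percentage points lower from compound 1 to compound 3 (beyond the scatter), so both aryl amides shown lie under the 2-(dimethylamino)ethyl amide, by different amounts. No measurement at hand speaks to what lies behind the effect of the swap from methyl to chloro.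

The compounds shown leave open whether chloro itself matters or whether any group other than methyl at this place would do the same, as a fluoro, a methoxy or a carboxylic acid there, or an unsubstituted phenyl, would tell. They also leave open how the 2-(dimethylamino)ethyl side responds to change, for instance with a longer chain ending in the same amine.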